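Replacing 4-fluorophenyl with 2-chlorophenyl in the hydroxamate series

The source may hold more compounds than are shown below. What is called first, only, known or untested is meant among the compounds shown, and "the series" means these compounds.

In a functional assay on Jurkat cells (Homo sapiens) for antiproliferative activity, read by MTT assay, with a stated time of 48 h (on this read-out lower numbers stand for stronger inhibition and higher numbers for weaker inhibition), compound 1 (`O=C(/C=C/c1ccc(Cn2cc(Nc3ncc(Cl)c(Nc4ccc(F)cc4)n3)cn2)cc1)NO`) gives 150 nM, compound 2 (`O=C(CCCCCCn1cc(Nc2ncc(Cl)c(Nc3ccc(F)cc3)n2)cn1)NO`) gives 120 nM and compound 3 (`O=C(CCCCCn1cc(Nc2ncc(Cl)c(Nc3ccc(F)cc3)n2)cn1)NO`) gives 60 nM. Compound 2 therefore holds the middle number of the three, and it lies within the scatter of both the others.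

The change under consideration leads to compound 4 (`O=C(CCCCCCn1cc(Nc2ncc(Cl)c(Nc3ccccc3Cl)n2)cn1)NO`): 2-chlorophenyl in place of 4-fluorophenyl on a nitrogen on an aromatic ring. In words, 2-chlorophenyl stands in place of 4-fluorophenyl on a nitrogen on an aromatic ring.

Among the compounds with values here, the only measured single-place step is a 2.0-fold lower number from compound 2 to compound 3 (0.30 log units; within the scatter). It lies within the scatter and concerns the saturated chain, so it bears only indirectly on this change. Within the data shown here, no measured compound varies the group on that nitrogen, and the data therefore give no direction for the change.

No shift beyond the scatter is expected in this assay, and the estimated change is no change at the digits printed from compound 2 to compound 4 (within the scatter). For compound 4 the expected value is 120 nM, with an estimated range of 40 nM to 350 nM.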

Compound 4, half-maximal inhibitory concentration: 250 nM
For compound 4 the middle estimate is 2.1-fold (0.32 log units) below the measured one; low and high end bracket the measured number.
By their numbers in this assay, from the lowest: compounds 3, 2, 1 and 4 (each within the scatter of the next, the first and the last beyond it).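

In this assay, the group on this nitrogen now shows a first measured effect (a 2.1-fold higher number from compound 2 to compound 4 (0.32 log units; beyond the scatter)). The step is modest, so 2-chlorophenyl is accepted here with a small loss and no collapse of activity. The exchange alters both the halogen and its place on the phenyl ring at once, so the result cannot assign the step to either change, and no measurement at hand accounts for it.

Open, going by these compounds, is how 2-fluorophenyl, 4-chlorophenyl or unsubstituted phenyl would read on this nitrogen, which would separate the halogen from its place on the ring. Also open, on these data alone, is whether the same exchange gives a step of similar size on the chain of compound 3 or of compound 1.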